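The source may hold more compounds than are shown below. What is called first, only, known or untested is meant among the compounds shown, and "the series" means these compounds.

Working notes on a series built around a shared core that carries a basic amine on a saturated chain.

In a functional assay on cells (Homo sapiens) for antiproliferative activity, read by MTT assay, with a stated time of 48 h (on this read-out lower numbers stand for stronger inhibition and higher numbers for weaker inhibition), compound 1 `CN(C)CCCn1c(N)c(-c2nc3ccccc3n2C)c2nc(C#N)c(C#N)nc21` gives 3670 nM. Compound 2 `CCN(CC)CCCn1c(N)c(-c2nc3ccccc3n2C)c2nc(C#N)c(C#N)nc21` differs from it by diethylamino in place of dimethylamino on a saturated chain carbon, three bonds along the chain from an aromatic nitrogen; in this assay compound 2 gives 6750 nM, and the step between them reads a 1.8-fold higher number from compound 1 to compound 2 (0.26 log units; within the scatter). Compound 3 `CN(C)CCCCn1c(-c2c(N)n(C)c3nc(C#N)c(C#N)nc23)nc2ccccc21` has a different core; the difference between the two cores is not broken down here. In this assay compound 3 gives 6480 nM, which sits within the scatter of compound 2.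

Compound 4 `CCN(CC)CCCCn1c(-c2c(N)n(C)c3nc(C#N)c(C#N)nc23)nc2ccccc21` is not yet measured. It differs from compound 3 by diethylamino in place of dimethylamino on a saturated chain carbon, four bonds along the chain from an aromatic nitrogen. Going by the values given here, this is the same kind of change as the one from compound 1 to compound 2, but sited four bonds along the chain from an aromatic nitrogen rather than three bonds; the change occurs twice in the set. Among the compounds with values here, a step of about a 1.5-fold higher number from compound 3 to compound 4 (0.17 log units; within the scatter) is expected, because the one earlier instance of this kind of change read a 1.8-fold higher number from compound 1 to compound 2 (0.26 log units; within the scatter). Compound 4 is therefore estimated at 9500 nM in this assay, with a range from 4500 nM to 20000 nM.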

Compound 4, half-maximal inhibitory concentration: 6950 nM
Estimate against measurement, compound 4: 1.4-fold (0.14 log units) above, within the range that was stated.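

In this assay, diethylamino in place of dimethylamino on a saturated chain carbon, four bonds along the chain from an aromatic nitrogen, reads a 1.1-fold higher number from compound 3 to compound 4 (0.03 log units; within the scatter). Set beside the earlier instance of this change, the new step does not differ from it beyond the scatter: the same change on two cores in this assay, a 1.8-fold higher number (0.26 log units; within the scatter) from compound 1 to compound 2 and a 1.1-fold higher number (0.03 log units; within the scatter) from compound 3 to compound 4, 1.7-fold (0.23 log units) apart, within the scatter of two such steps

The change therefore reads alike on these two cores, with neither step beyond the scatter, but two pairs cannot show that it has a real effect in this assay, nor that the agreement would hold on any further core, and core and chain place differ together between the pairs, so neither can be judged alone.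

The compounds shown leave open how a primary amine or a hydroxyl group would read in place of dimethylamino or diethylamino. As far as these compounds go, a longer chain on either core also remains open, as does whether any such group would give a step beyond the scatter.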